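Series notes: removing the ring hydroxy of compound 1

This account rests on a few compounds, and the source may have more. Where it says the series, first, only, none or still open, it means among the compounds named here.

Of the compounds shown here, two carry numbers so far. In an assay on cell membranes for displacement of a labelled ligand from Sigma non-opioid intracellular receptor 1 (Cavia porcellus), read by scintillation counting, with a stated time of 120 min (a higher number here means a weaker inhibitor, a lower number a stronger inhibitor), compound 1 `OC1CC(NCc2ccccc2)CCc2sccc21` gives 737 nM, the highest of the two values. Compound 2 `Nc1ccc2c(c1)CCC(NCc1ccccc1)CC2` gives 470 nM in this assay; its gap to compound 1 lies within the usual scatter, so the two numbers are not told apart. For the measured compounds named here, no pair of measured compounds differs in only one place, and no single change has yet been given a size.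

Compound 3 `c1ccc(CNC2CCc3ccsc3CC2)cc1` remains to be measured in this assay. Against compound 1 it shows (hydrogen in place of hydroxy on a saturated ring carbon), hydrogen in place of hydroxy on a saturated ring carbon; the rest of the shared core and the group of 8 heavy atoms on the ring atom are kept. Going by the values given here, with no measured step to lean on, the expectation for this change is a small lowering of the inhibition constant, which may not clear the scatter. The expected step is a 1.8-fold lower number from compound 1 to compound 3 (0.27 log units; within the scatter), estimated without precedent in the series. For compound 3 the expected value is 400 nM, with a range from 120 nM to 1500 nM.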

Compound 3, inhibition constant: 79 nM
For compound 3 the middle estimate is 5.1-fold (0.70 log units) above the measured one; the measured number lies below the stated range.
By their numbers in this assay, from the lowest: compound 3; then compounds 2 and 1 (each within the scatter of the next).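

Series notes, reading the step: In this assay hydrogen in place of hydroxy on a saturated ring carbon gives a 9.3-fold lower number from compound 1 to compound 3 (0.97 log units; beyond the scatter) and so provides the first single change in this series with a measured size. The position, two ring bonds from the ring atom that bears the group of 8 heavy atoms, is therefore not indifferent to what it carries, and the hydroxy is not required for a low number in this assay, since the shared core and that group are kept. No measurement at hand bears on why the number falls with this change.

Going by these compounds, the step rests on a single pair, with only hydroxy and hydrogen compared on this carbon, so whether it follows the oxygen itself or the hydrogen on it stays open, and a methoxy group there would separate the two. On these data alone, a fluorine or an amine on the same carbon would show whether other groups give numbers closer to compound 1 or to compound 3, and whether the same change gives a step of similar size on another core also remains open.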